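Fluoro to Methyl: A Small Swap, Cytotoxicity in View

This account rests on a few compounds, and the source may have more. Where it says the series, first, only, none or still open, it means among the compounds named here.

Compound 1 (`FC(F)(F)c1cccc(NC(=S)Nc2ccc(I)cc2)c1`) gives 10000 nM
Compound 2 (`Fc1ccc(NC(=S)Nc2cccc(C(F)(F)F)c2)cc1Cl`) gives 8000 nM
Compound 3 (`COc1cccc(NC(=S)Nc2cccc(C(F)(F)F)c2)c1`) gives 26000 nM

In an ADME assay on MT4 cells (Homo sapiens) for cytotoxicity (a lower number here means that less compound is tolerated, a higher number that more compound is tolerated), compound 2 gives 8000 nM and sits at the low end of these numbers. That places it within the scatter of compound 1 (10000 nM) and clearly under compound 3 (26000 nM) on this scale.

Compound 4 (`Cc1ccc(NC(=S)Nc2cccc(C(F)(F)F)c2)cc1Cl`) has methyl in place of fluoro on an aromatic carbon, ortho to a chloro group and para to a large group. Among the compounds with values here, no measured pair shows this swap, so the data offer no direct guide. The expected step (a 1.3-fold higher number from compound 2 to compound 4 (0.10 log units; within the scatter)) is a slight rise that stays within the scatter. For compound 4 the estimated value in this assay is 10000 nM (expected range 4000 nM to 25000 nM).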

Compound 4, half-maximal cytotoxic concentration: 20000 nM
The estimate for compound 4 lay 2.0-fold (0.30 log units) below the measured number, and the stated range covers the measured number.
By their numbers in this assay, from the lowest: compounds 2, 1, 4 and 3 (each within the scatter of the next, the first and the last beyond it).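

In this assay, placing methyl in place of fluoro on this aromatic carbon, ortho to a chloro group and para to a large group, gives a 2.5-fold higher number from compound 2 to compound 4 (0.40 log units; beyond the scatter) as a modest step. Within the data shown here, the earlier compounds held no such pair, so this is the first sign that this position can shift tolerated concentration through a single-atom change. Nothing measured here accounts for the step. On these data alone, what an amine or a longer chain on this carbon would give remains open, as does whether the step holds without the chloro group.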